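Hydroxy on the ring of compound 1: expected cytotoxicity step

The compounds below may be only part of what the source reports. "The series", "measured", "known", "first", "only" and "open" are said of these compounds alone.

Going by the values given here, in a functional assay on Lu1 cells (Homo sapiens) for cytotoxicity, read by colorimetric assay and neutral red uptake, with a stated time of 72 h (a lower number here means a stronger inhibitor, a higher number a weaker inhibitor), compound 1 `CO[C@@H](C(=O)N[C@H]1CCCCNC1=O)[C@H](O)[C@@H](O)[C@H](O)/C=C/C(C)(C)C` gives 4300 nM and is the only compound with a number so far.

Compound 2 `CO[C@@H](C(=O)N[C@H]1CCCCNC1=O)[C@@H]1OC(C)(C)O[C@H](/C=C/C(C)(C)C)[C@@H]1O` is reported only as a limit of > 150000 nM and not as a number.

Among the compounds with values here, no measured step is therefore available for scaling an expectation.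

Compound 3 `CO[C@@H](C(=O)N[C@H]1CC[C@@H](O)CNC1=O)[C@H](O)[C@@H](O)[C@H](O)/C=C/C(C)(C)C` keeps the core of compound 1 and differs at one place: hydroxy in place of hydrogen on a saturated ring carbon with hydroxy in place of hydrogen on a saturated ring carbon, two ring bonds from the ring nitrogen and three ring bonds from the ring atom that bears a large group. Within the data shown here, no measured compound carries a substituent at this place. The working expectation in this assay is thus no change beyond the scatter, in either direction.

The expected step is a 1.2-fold lower number from compound 1 to compound 3 (0.09 log units; within the scatter) and is an estimate only.

With compound 1 at 4300 nM as the sole anchor, the range is kept wide.

Compound 3 is expected at 3500 nM with an estimated range of 700 nM to 20000 nM for now.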

Compound 3, half-maximal inhibitory concentration: 23400 nM
Compound 3: middle estimate off by 6.7-fold (0.83 log units), on the low side; measured number above the stated range.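

Hydroxy on a saturated ring carbon, two ring bonds from the ring nitrogen and three ring bonds from the ring atom that bears a large group, is not a silent change in this assay: going from 2-oxoazepan-3-yl to 6-hydroxy-2-oxoazepan-3-yl gives a 5.4-fold higher number from compound 1 to compound 3 (0.74 log units; beyond the scatter). This is the first measured step in the series and the first reading at this ring place, so the place is shown to respond to substitution, with compound 3 the weaker inhibitor by a modest step. Going by these compounds alone, compound 2 is reported as a limit and not as a number, so no step involving it can be read: the limit of > 150000 nM in this assay, at which 1 of the 3 values shown sits.

With a single substituent at this place, the data do not separate an effect of hydroxy itself from an effect of any added group, and a fluorine, a methoxy or an amine on the same ring carbon would address that. Also open, on these data alone, is how the opposite arrangement of the hydroxy on this ring carbon would read, and whether the step carries over to other ring carbons.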